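Oxazole to Thiazole Swap and Liver Microsomal Clearance

The source may report more compounds than this note shows. Statements on the series, on what has been measured and on what is new or still open speak of the compounds shown alone.

Compound 1 `Cc1c(Cc2ccc(-c3cocn3)cc2)cc(C(=O)N[C@H]2CCCC[C@@H]2O)c(=O)n1C` and compound 2 `Cc1c(Cc2ccc(-c3cscn3)cc2)cc(C(=O)N[C@H]2CCCC[C@@H]2O)c(=O)n1C` share one core and differ in a single group. In an ADME assay on microsomes from liver (Homo sapiens) for metabolic stability (on this read-out lower numbers stand for slow clearance and higher numbers for fast clearance), compound 1 gives 17 mL/min/kg. In this assay compound 2 gives 26 mL/min/kg. The step of a 1.5-fold higher number from compound 1 to compound 2 (0.18 log units; within the scatter) follows the change (1,3-thiazol-4-yl in place of 1,3-oxazol-4-yl on an aromatic carbon).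

Compound 3 `Cc1cnc(C(=O)N[C@H]2CCOC[C@@H]2O)cc1Cc1ccc(-c2cocn2)cc1` is built on another core; the difference between the two cores is not broken down here. In this assay compound 3 reports only a limit of the assay, < 8 mL/min/kg, namely (the limit of < 8 mL/min/kg in this assay, at which 1 of the 3 values shown sits).

Compound 4 `Cc1cnc(C(=O)N[C@H]2CCOC[C@@H]2O)cc1Cc1ccc(-c2cscn2)cc1`, not yet measured, arises from compound 3 by the change (1,3-thiazol-4-yl in place of 1,3-oxazol-4-yl on an aromatic carbon), the same change as that between compound 1 and compound 2, at the same place on the ring.

For compound 4 a step of an at least 1.1-fold higher number from compound 3 to compound 4 (0.05 log units; that floor lies within the scatter) is expected, resting on the earlier step of a 1.5-fold higher number from compound 1 to compound 2 (0.18 log units; within the scatter) that stayed within the scatter. Since compound 3 shows only a limit, the result for compound 4 may again be reported as a limit rather than a number. Compound 4 is estimated to give 9 mL/min/kg in this assay, with a likely range from 4 mL/min/kg to 18 mL/min/kg.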

Compound 4, clearance: < 8 mL/min/kg
Compound 4 was reported as a limit; the forecaster's own chance of this, stated with the estimate: 45%; middle value at least 1.1-fold (0.05 log units) away from the limit.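

In this assay compound 3 and compound 4 both report only a limit of the assay, so no step can be read between them: the limit of < 8 mL/min/kg in this assay, at which 2 of the 4 values shown sit.

The compounds shown leave open whether, and by how much, 1,3-thiazol-4-yl in place of 1,3-oxazol-4-yl shifts clearance on the core of compound 3.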